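Cutting back the chain of compound 3

The compounds below may be only part of what the source reports. "The series", "measured", "known", "first", "only" and "open" are said of these compounds alone.

Measured in a functional assay on PC-3 cells (Homo sapiens) for cytotoxicity; a higher number here means a weaker inhibitor, a lower number a stronger inhibitor:
- compound 1 `COc1ccc2nc(NC(=O)CCCCC(=O)NO)sc2c1`: 15.3 ug/mL
- compound 2 `CS(=O)(=O)c1ccc2nc(NC(=O)CCCCC(=O)NO)sc2c1`: > 30 ug/mL, a limit
- compound 3 `Cc1ccc2nc(NC(=O)CCCCCCC(=O)NO)sc2c1`: 0.53 ug/mL

Compound 3 holds the lowest of the two actual numbers, and compound 1, at 15.3 ug/mL, is clearly the weaker of the two. The change to compound 4 `Cc1ccc2nc(NC(=O)CCCCC(=O)NO)sc2c1` is hydroxycarbamoyl in place of 2-(hydroxycarbamoyl)ethyl on a saturated chain carbon, four bonds along the chain from a carbonyl carbon. It puts hydroxycarbamoyl in place of 2-(hydroxycarbamoyl)ethyl, which gives compound 4 the chain of compound 1 and compound 2.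

Among the measured compounds shown here, the one measured step, an at least 1.9-fold higher number from compound 1 to compound 2 (0.29 log units; that floor lies within the scatter), concerns a different place and does not measure this change. The best guide is compound 1, with the same chain, at 15.3 ug/mL. A clear rise in this assay, beyond the scatter, is therefore expected. The expected step is a 19-fold higher number from compound 3 to compound 4 (1.28 log units; beyond the scatter). For compound 4 the estimated value is 10 ug/mL, with an expected range of 3 ug/mL to 30 ug/mL.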

Compound 4, half-maximal inhibitory concentration: 6.23 ug/mL
For compound 4 the middle estimate is 1.6-fold (0.21 log units) above the measured one; the measured number falls inside the stated range.
By their numbers in this assay, from the lowest: compound 3; then compound 4; then compound 1. At a limit, above all of these: compound 2.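

With the aromatic methyl group held fixed, this assay now isolates the chain change: cutting it back gives a 12-fold higher number from compound 3 to compound 4 (1.07 log units; beyond the scatter). On the shorter chain, the group on the aromatic carbon also counts, since methyl in place of methoxy gives a 2.5-fold lower number from compound 1 to compound 4 (0.39 log units; beyond the scatter). Methyl in place of methylsulfonyl gives an at least 4.8-fold lower number from compound 2 to compound 4 (0.68 log units; beyond the scatter), but this step starts from a limit, not a number: the limit of > 30 ug/mL in this assay, at which 1 of the 4 values shown sits.

The compounds shown leave open how a chain longer than that of compound 3 would compare. They also leave open how an amine or a carboxylic acid on that aromatic carbon would compare with methyl.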